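A few compounds are considered here, and "the series" means these few. Any claim that something is new, unique, unknown or untested is made for them only; others in the source may bear on it.

Compound 3, `CN1CCN(c2cccc3c2C[C@H](CN(C)[C@H]2CCCc4cccnc42)NC3)CC1`, carries a methyl on the amine nitrogen of its piperazine ring, and in a functional assay on CCRF-CEM cells for antagonist activity at C-X-C chemokine receptor type 4 (Homo sapiens), read by calcium flux, with stated times of 25 min and 90 s (a higher number here means a weaker inhibitor, a lower number a stronger inhibitor), compound 3 gives 29.6 nM. Its companion compound 1, `CC(C)N1CCN(c2cccc3c2C[C@H](CN(C)[C@H]2CCCc4cccnc42)NC3)CC1`, bears an isopropyl at the same nitrogen, and in this assay compound 1 gives 16.9 nM. These two numbers sit together: the step of a 1.8-fold higher number from compound 1 to compound 3 (0.24 log units; within the scatter) is within the scatter, so neither can be set above the other. The third member, compound 2, `CN(C[C@H]1Cc2c(cccc2N2CCN(c3cccc(C(F)(F)F)c3)CC2)CN1)[C@H]1CCCc2cccnc21`, carries a 3-(trifluoromethyl)phenyl at that nitrogen, and for compound 2 this assay reports only a limit, > 16700 nM. That limit of > 16700 nM in this assay, at which 1 of the 3 values shown sits, is why the steps of an at least 980-fold higher number from compound 1 to compound 2 (2.99 log units; beyond the scatter) and an at least 560-fold lower number from compound 2 to compound 3 (2.75 log units; beyond the scatter) are so large: the aryl substituent falls outside what this assay can measure.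

Compound 4, `CCN1CCN(c2cccc3c2C[C@H](CN(C)[C@H]2CCCc4cccnc42)NC3)CC1`, differs from compound 3 by methyl in place of hydrogen on a saturated chain carbon bound to an amine nitrogen in a ring, so that the methylpiperazine becomes an ethylpiperazine. Within the data shown here, the only step that bears on this change is the one between methyl and isopropyl, a 1.8-fold higher number from compound 1 to compound 3 (0.24 log units; within the scatter), which lies within the scatter; ethyl sits between those two groups in size, and no step beyond the scatter is expected. Compound 4 is therefore estimated at 22 nM, in a range from 9 nM to 55 nM, which means an expected step of a 1.3-fold lower number from compound 3 to compound 4 (0.13 log units; within the scatter).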

Compound 4, half-maximal inhibitory concentration: 13.8 nM
Compound 4: the middle estimate sits 1.6-fold (0.20 log units) above what was measured; measured number inside the range.
By their numbers in this assay, from the lowest: compounds 4, 1 and 3 (each within the scatter of the next, the first and the last beyond it). At a limit, above all of these: compound 2.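

In this assay, among these compounds, the added methyl gives the first step among the small alkyl groups on the amine nitrogen in a ring that lies beyond the scatter, with a 2.1-fold lower number from compound 3 to compound 4 (0.33 log units; beyond the scatter) as a modest step. Set against the isopropyl, however, the ethyl stays within the scatter, with a 1.2-fold lower number from compound 1 to compound 4 (0.09 log units; within the scatter) and no order between the two, and since compound 1 and compound 3 also sit within the scatter of each other, these three alkyl groups give only a shallow spread and no clean trend by size. The figure for compound 2 is a limit, so an at least 1200-fold lower number from compound 2 to compound 4 (3.08 log units; beyond the scatter) gives only a bound on how far the aryl group stands from the ethyl: the limit of > 16700 nM in this assay, at which 1 of the 4 values shown sits.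

On these data alone, it remains open whether a bare hydrogen on this nitrogen, a cyclopropyl group, a longer chain such as n-propyl or a 2-hydroxyethyl group would stay in the range of the small alkyl groups. As far as these compounds go, it is equally open whether an unsubstituted phenyl or a benzyl group would share the fate of the 3-(trifluoromethyl)phenyl group, or whether the trifluoromethyl group plays a part of its own.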